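The source may hold more compounds than are shown below. What is called first, only, known or untested is meant among the compounds shown, and "the series" means these compounds.

Compound 1, `C=C(Br)C(=O)Nc1ccc(C(=O)/C=C/c2ccccc2OC)cc1`: 370 nM in a functional assay on FM3A cells (Mus musculus) for antiproliferative activity, with a stated time of 48 h; on this read-out higher numbers stand for weaker inhibition and lower numbers for stronger inhibition
Compound 2, `C=C(Br)C(=O)Nc1ccc(C(=O)/C=C/c2cccc(OC)c2OC)cc1`: 550 nM
Compound 3, `C=C(Br)C(=O)Nc1ccc(C(=O)/C=C/c2cc(OC)cc(OC)c2)cc1`: 2000 nM

All three share a core in which a bromoacrylamide-bearing phenyl ketone is joined through a double bond to a second aromatic ring, and they differ only in the methoxy groups on that second ring. From compound 1 to compound 2 the change is methoxy in place of hydrogen on an aromatic carbon. It gave a 1.5-fold higher number from compound 1 to compound 2 (0.17 log units; within the scatter). Compound 3 stands highest of the three numbers, and its gaps to compound 2 and to compound 1 are beyond the scatter. How the core of compound 3 differs from that of compound 1 is not broken down here.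

Compound 4, `C=C(Br)C(=O)Nc1ccc(C(=O)/C=C/c2cc(OC)c(OC)c(OC)c2)cc1`, has not yet been measured in this assay. It differs from compound 3 by methoxy in place of hydrogen on an aromatic carbon. Among the compounds with values here, this is the same kind of change as the one from compound 1 to compound 2, though the surroundings are not the same: in compound 2 the entering methoxy sits ortho to a methoxy group and meta to a large group, whereas in compound 4 it sits ortho to two methoxy groups and para to a large group.

Within the data shown here, the step from compound 3 to compound 4 is expected to be a 1.1-fold higher number from compound 3 to compound 4 (0.04 log units; within the scatter), a small step in line with the earlier one, because the only measured example of this kind of change gave a 1.5-fold higher number from compound 1 to compound 2 (0.17 log units; within the scatter). With that, compound 4 is estimated to give 2200 nM, with a range from 800 nM to 6000 nM.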

Compound 4, half-maximal inhibitory concentration: 1800 nM
For compound 4 the middle estimate is 1.2-fold (0.09 log units) above the measured one; low and high end bracket the measured number.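

Adding a methoxy group to compound 3, at the place ortho to two methoxy groups and para to a large group, gave a 1.1-fold lower number from compound 3 to compound 4 (0.05 log units; within the scatter) in this assay, so this step is too small to be told apart from repeat-to-repeat variation. Set beside the earlier step, the same change behaves alike on the two cores, with no detectable difference between them: the same change on two cores in this assay, a 1.5-fold higher number (0.17 log units; within the scatter) from compound 1 to compound 2 and a 1.1-fold lower number (0.05 log units; within the scatter) from compound 3 to compound 4, 1.7-fold (0.22 log units) apart, within the scatter of two such steps This shows only that on these two cores the added methoxy leaves the number within the scatter; it does not show a general rule for other cores, and with just two small steps, at different places on the ring, it cannot reveal a modest dependence on the core or explain why the change does so little.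

All the compounds shown carry only methoxy groups as substituents on the second aromatic ring, so it remains open whether a hydroxyl, an amine, a carboxylic acid or a longer chain such as ethoxy at the same place would shift the number beyond the scatter. From the compounds shown here alone, it is also open whether the same small step would appear with a different group in place of the bromoacrylamide, or in cells other than those used here.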